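A few compounds are considered here, and "the series" means these few. Any claim that something is new, unique, unknown or untested is made for them only; others in the source may bear on it.

Measured in an ADME assay on HFF cells (Homo sapiens) for cytotoxicity, with a stated time of 72 h (a higher number here means that more compound is tolerated, a lower number that less compound is tolerated), the compounds stand as follows:
compound 1 `Cc1ccc(C(=O)Nc2cc(Cl)cnc2C(=O)O)cc1` gives 18200 nM
compound 2 `O=C(Nc1cc(Cl)cnc1C(=O)O)c1ccccc1` gives > 50000 nM as a limit
compound 3 `COc1cccc(C(=O)Nc2cc(Cl)cnc2C(=O)O)c1` gives > 50000 nM as a limit

Compound 2 has only a limit in this assay and stands at the limit of > 50000 nM in this assay, at which 2 of the 3 values shown sit, so there is no exact number to start from. Compound 4 `COc1ccccc1C(=O)Nc1cc(Cl)cnc1C(=O)O` differs from it in one place: methoxy in place of hydrogen on an aromatic carbon. Going by the values given here, two measured steps bear on this. The same exchange at another carbon of that ring gives a step that the two limits leave unreadable from compound 2 to compound 3, which shows no size. Among the compounds with values here, the one readable step is an at least 2.7-fold higher number from compound 1 to compound 2 (0.43 log units; beyond the scatter), where hydrogen replaces methyl, so a group on this ring went with less compound tolerated in compound 1, but compound 3 goes against that as a general pattern. A modest fall at most therefore seems likely. The expected step is an at least 1.2-fold lower number from compound 2 to compound 4 (0.09 log units; that floor lies within the scatter) and may not exceed the scatter. Compound 4 is estimated at 40000 nM, with an expected range from 15000 nM to 70000 nM in this assay.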

Compound 4, half-maximal cytotoxic concentration: > 50000 nM
Compound 4 was reported as a limit (the forecaster's own chance of this, stated with the estimate: 65%); at least 1.2-fold (0.09 log units) between middle value and limit.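

In this assay compound 4 gives > 50000 nM as a limit. Compound 2 also stands at a limit, so no step between compound 2 and compound 4 can be read: the limit of > 50000 nM in this assay, at which 3 of the 4 values shown sit.

The compounds shown leave open how much compound is actually tolerated for compound 2, compound 3 and compound 4, and so whether methoxy in place of hydrogen changes anything.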